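Trifluoromethyl to acetamido: working notes on compound 3

This account rests on a few compounds, and the source may have more. Where it says the series, first, only, none or still open, it means among the compounds named here.

Of the compounds shown here, two have numbers so far in a functional assay on QGY-7703 cells (Homo sapiens) for cytotoxicity, read by MTT assay, with a stated time of 24 h; on this read-out higher numbers stand for weaker inhibition and lower numbers for stronger inhibition. Compound 1 (`Cc1ccc(S(=O)(=O)N2C/C(=C\c3cccnc3)C(=O)/C(=C/c3ccccc3C(F)(F)F)C2)cc1`) gives 6170 nM there, and compound 2 (`O=C1/C(=C/c2cccnc2)CN(S(=O)(=O)c2ccc(C(F)(F)F)cc2)C/C1=C\c1ccccc1C(F)(F)F`) gives the lower of the two numbers (1500 nM). Compound 3 (`CC(=O)Nc1ccc(S(=O)(=O)N2C/C(=C\c3cccnc3)C(=O)/C(=C/c3ccccc3C(F)(F)F)C2)cc1`) keeps the shared core of compound 2 and changes one group (acetamido in place of trifluoromethyl on an aromatic carbon): acetamido in place of trifluoromethyl on an aromatic carbon, para to a large group.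

Among the compounds with values here, only one measured step bears on this change (a 4.1-fold lower number from compound 1 to compound 2 (0.61 log units; beyond the scatter)). It is modest but beyond the scatter, and it involves trifluoromethyl in place of methyl at the same place. Compound 2 is thus the better of the two, and compound 3 gives up its trifluoromethyl. Within the data shown here, no acetamido compound has been measured, so this single step is a thin guide and even the direction remains uncertain. A modest move towards a higher number is expected, with the estimated step being a 2.3-fold higher number from compound 2 to compound 3 (0.37 log units; beyond the scatter) in size. For compound 3 the expected value is 3500 nM in this assay, with an estimated range of 1000 nM to 12000 nM.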

Compound 3, half-maximal inhibitory concentration: 5380 nM
The estimate for compound 3 lay 1.5-fold (0.19 log units) below the measured number, and the stated range covers the measured number.
By their numbers in this assay, from the lowest: compound 2; then compounds 3 and 1 (each within the scatter of the next).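

In this assay, replacing trifluoromethyl with acetamido on an aromatic carbon, para to a large group, gives a 3.6-fold higher number from compound 2 to compound 3 (0.55 log units; beyond the scatter), so a second group at this place now fails to match trifluoromethyl. The other step at this place, a 1.1-fold lower number from compound 1 to compound 3 (0.06 log units; within the scatter), lies within the scatter, so methyl and acetamido cannot be told apart here despite their different make-up, with acetamido bringing a hydrogen-bond donor and a hydrogen-bond acceptor. Of the three groups, only trifluoromethyl separates from the others, a pattern that rests on these three compounds alone, and no measurement at hand accounts for it.

Going by these compounds, how a chlorine, a nitrile or a free amine at this place would compare with trifluoromethyl stays open, so the lower number of compound 2 cannot yet be read as particular to trifluoromethyl or as shared with other groups. Also open, on these data alone, is whether the same gaps between these three groups would hold with a different group in place of the 2-(trifluoromethyl)benzylidene part of the shared core, or in other cell lines.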